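Swapping the heteroaryl group in a series held at a limit

The compounds below may be only part of what the source reports. "The series", "measured", "known", "first", "only" and "open" are said of these compounds alone.

In an ADME assay on L6 cells (Rattus norvegicus) for cytotoxicity, read by resazurin assay, with a stated time of 72 h (a lower number here means a stronger inhibitor, a higher number a weaker inhibitor), compound 1 (`OC(c1ccc(Cl)cc1)(c1cccnc1)c1nccs1`) gives > 100000 nM as a limit of the assay. Compound 2 (`OC(c1ccc(Cl)cc1)(c1cccnc1)c1cnc(Cl)s1`) gives > 100000 nM as a limit too. For the measured compounds named here, the only measured step is a step that the two limits leave unreadable from compound 1 to compound 2 and it offers no size to carry forward. Compound 2 therefore stands at the limit of > 100000 nM in this assay, at which 2 of the 2 values shown sit, and no number places it. Compound 3 (`OC(c1ccc(Cl)cc1)(c1cccnc1)c1cncnc1`) carries pyrimidin-5-yl in place of 2-chloro-1,3-thiazol-5-yl (pyrimidin-5-yl in place of 2-chloro-1,3-thiazol-5-yl on a saturated chain carbon bound to two aromatic carbons and an oxygen on a saturated carbon). With compound 2 resting on > 100000 nM as a limit, no step beyond the scatter is expected in this assay in either direction. The expected step is a number no higher from compound 2 to compound 3 (the limit leaves the size open) and it remains an estimate. For compound 3 the estimated value is 100000 nM with an expected range from 40000 nM to 200000 nM and another report as a limit is likely.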

Compound 3, half-maximal inhibitory concentration: > 100000 nM
Compound 3: no number, only a limit; the forecaster's own chance of this, stated with the estimate: 75%; the middle value lies on the limit itself.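

For the compounds shown here, compound 1, compound 2 and compound 3 share one limit, so no step among them can be read: the limit of > 100000 nM in this assay, at which 3 of the 3 values shown sit.
The compounds shown leave open whether any heteroaryl group on the shared core gives a number in this assay at all.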